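Benzoyl substitution on the chlorinated hydrazone core

This account rests on a few compounds, and the source may have more. Where it says the series, first, only, none or still open, it means among the compounds named here.

Measured so far:
- compound 1 `Cc1cc2c(cc1C)C(Cl)=C(/C=N/NC(=O)c1ccccc1)CCC2`: > 100000 nM
- compound 2 `Cc1ccc(C(=O)N/N=C/C2=C(Cl)c3cc(C)c(C)cc3CCC2)cc1`: 28800 nM
- compound 3 `Cc1cc2c(cc1C)C(Cl)=C(/C=N/NC(=O)c1ccccc1N)CCC2`: 810 nM

In a functional assay (MiaPaCa cells, Homo sapiens) for inhibition, read by sulforhodamine B assay, with a stated time of 48 h (a lower number here means a stronger inhibitor of growth, a higher number a weaker inhibitor of growth), compound 1 gives only a limit, > 100000 nM; this is the limit of the assay and not a number, as the evidence shows (the limit of > 100000 nM in this assay, at which 1 of the 3 values shown sits). Every change so far made on the benzoyl ring of compound 1 has lowered the number: an at least 3.4-fold lower number from compound 1 to compound 2 (0.54 log units; beyond the scatter) and an at least 120-fold lower number from compound 1 to compound 3 (2.09 log units; beyond the scatter). Between those two, a 36-fold lower number from compound 2 to compound 3 (1.55 log units; beyond the scatter).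

Compound 4 `Cc1cc2c(cc1C)C(Cl)=C(/C=N/NC(=O)c1cccc(C(F)(F)F)c1)CCC2` differs from compound 1 by trifluoromethyl in place of hydrogen on an aromatic carbon. Within the data shown here, no trifluoromethyl analogue has yet been run in this assay, so the two steps from compound 1 are the only guide, and both point downward. Among the measured compounds shown here, a step of the smaller kind is expected, comparable to the one from compound 1 to compound 2, with a real chance that compound 4 also returns only a limit. For compound 4 the estimate in this assay is 30000 nM, between 5000 nM and 150000 nM, meaning an expected at least 3.3-fold lower number from compound 1 to compound 4 (0.52 log units; beyond the scatter).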

Compound 4, concentration for 50% growth inhibition: 12200 nM
The estimate for compound 4 lay 2.5-fold (0.39 log units) above the measured number; low and high end bracket the measured number.
By their numbers in this assay, from the lowest: compound 3; then compound 4; then compound 2. At a limit, above all of these: compound 1.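

Working from the ring place meta to a large group, trifluoromethyl brings the series a measured number in this assay, with an at least 8.1-fold lower number from compound 1 to compound 4 (0.91 log units; beyond the scatter). This is the first change shown at this place, and it shows that a group of 4 heavy atoms with no hydrogen-bond donor or acceptor is enough to take the compound off the limit. Its full size cannot be read because the step starts from a limit: the limit of > 100000 nM in this assay, at which 1 of the 4 values shown sits.

Still open, from the compounds shown here alone, is whether the drop belongs to the place or to the group, since trifluoromethyl appears at this one ring place only. Also open, going by these compounds, is how an amine, a nitrile or a carboxylic acid would read at the same place, which would show whether the amino gain of compound 3 carries over there.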